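The source may report more compounds than this note shows. Statements on the series, on what has been measured and on what is new or still open speak of the compounds shown alone.

Three compounds share one core and differ only in the group on the aromatic ring that sits on the carbon with a double bond to nitrogen. Compound 1 `COc1ccc(/C=N/NC(=S)NC(C)(C)[C@H]2CC=C(C)CC2)cc1` gives 43800 nM in a functional assay on NCI/ADR-RES cells (Homo sapiens) for inhibition, read by sulforhodamine B assay, with a stated time of 48 h; on this read-out lower numbers stand for stronger inhibition of growth and higher numbers for weaker inhibition of growth. Compound 2 `CC1=CC[C@H](C(C)(C)NC(=S)N/N=C/c2ccc(N(C)C)cc2)CC1` reaches only a limit of the assay in this assay, > 100000 nM. Compound 3 `CC1=CC[C@H](C(C)(C)NC(=S)N/N=C/c2ccc(F)cc2)CC1` likewise reaches only a limit in this assay, > 100000 nM. Compound 3 therefore stands at the weak end of the numbers shown, with no true number known for it. The steps of an at least 2.2-fold higher number from compound 1 to compound 2 (0.35 log units; beyond the scatter) and an at least 2.2-fold higher number from compound 1 to compound 3 (0.35 log units; beyond the scatter) both run from a number to a limit, and the step that the two limits leave unreadable from compound 2 to compound 3 cannot be read since (the limit of > 100000 nM in this assay, at which 2 of the 3 values shown sit).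

Compound 4 `CC1=CC[C@H](C(C)(C)NC(=S)N/N=C/c2ccco2)CC1` brings the change furan-2-yl in place of 4-fluorophenyl on a carbon with a double bond to nitrogen: furan-2-yl enters where 4-fluorophenyl leaves. Within the data shown here, no measured step exchanges the ring itself; the measured steps only swap substituents on that ring, and both swaps away from methoxy ended at the limit. Compound 4 is thus expected to remain near that limit, an expected step of a number no higher from compound 3 to compound 4 (the limit leaves the size open). The estimate for compound 4 is 100000 nM, within 30000 nM to 300000 nM.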

Compound 4, concentration for 50% growth inhibition: 9800 nM
Compound 4: the middle estimate sits 10-fold (1.01 log units) above what was measured; measured number below the stated range.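

In this assay, among these compounds, the earlier compounds only swapped substituents on a six-membered aromatic ring, whereas exchanging the ring itself on a carbon with a double bond to nitrogen gives an at least 10-fold lower number from compound 3 to compound 4 (1.00 log units; beyond the scatter). Among the compounds shown here, the furan-2-yl group also improves on the one earlier compound with a true number, with a 4.5-fold lower number from compound 1 to compound 4 (0.65 log units; beyond the scatter), so this position can tolerate a change of ring and growth inhibition can improve with it. The full size of the first step stays unknown because compound 3 sits at a limit: the limit of > 100000 nM in this assay, at which 2 of the 4 values shown sit.

The compounds shown leave open whether the ring oxygen or the smaller five-membered ring goes with the stronger inhibition. A thiophen-2-yl group, with sulfur in place of that oxygen, or an unsubstituted phenyl group at this place would help to separate these possibilities.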